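Replacing a Pyrazole with Pyridine on a Thienylmethyl Amide

This account rests on a few compounds, and the source may have more. Where it says the series, first, only, none or still open, it means among the compounds named here.

Of the compounds shown here, three have been measured in an assay on HEK293 cells for agonist activity at transient receptor potential cation channel subfamily M member 8 (Homo sapiens), read by fluorescence and calcium flux, with a stated time of 15 min; on this read-out higher numbers stand for an effect only at larger amounts of compound and lower numbers for an effect already at smaller amounts. Compound 1 `CCN(Cc1cccs1)C(=O)c1cc2cc(C)ccc2o1` gives 120 nM, and compound 3 `CCN(Cc1ccco1)C(=O)COc1ccc(C)cc1` gives 489 nM. Compound 2 `Cc1ccc(OCC(=O)N(Cc2cccs2)c2c[nH]nc2C)cc1` gives 0.4 nM, the lowest of the three numbers; its gap to compound 1 and its still larger gap to compound 3 both lie beyond the usual scatter, so compound 2 stands as the most potent of the three.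

Compound 4 `Cc1ccc(OCC(=O)N(Cc2cccs2)c2ccncc2)cc1` has not yet been measured. It differs from compound 2 in one place: pyridin-4-yl in place of 3-methyl-1H-pyrazol-4-yl on an amide-type nitrogen. The group that leaves carries a hydrogen-bond donor, the group that enters carries none; how much weight that donor carries in this assay cannot be read from the three numbers shown, since no other measured pair isolates it.

Given that compound 2 gives 0.4 nM and nothing else constrains the change, the step from compound 2 to compound 4 is expected to be a move toward higher numbers, a 25-fold higher number from compound 2 to compound 4 (1.40 log units; beyond the scatter). Compound 4 is therefore estimated at 10 nM, within a range from 1 nM to 120 nM.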

Compound 4, half-maximal effective concentration: 52 nM
Estimate against measurement, compound 4: 5.2-fold (0.72 log units) below, and the stated range covers the measured number.
By their numbers in this assay, from the lowest: compound 2; then compound 4; then compound 1; then compound 3.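

In this assay, for the compounds shown here, putting pyridin-4-yl in place of 3-methyl-1H-pyrazol-4-yl on the amide-type nitrogen gives a 130-fold higher number from compound 2 to compound 4 (2.11 log units; beyond the scatter), the first measured step that isolates this position and a large one. The two groups have the same number of heavy atoms and of hydrogen-bond acceptors, so the position responds strongly to a change that leaves those counts untouched, while the ring size, the ring hetero atoms, the methyl group and the hydrogen-bond donor all change at once. Nothing measured here explains the size of this step.

What the compounds shown leave open is which of those differences carries the step. A 1H-pyrazol-4-yl group without the methyl, or a phenyl ring, on the same nitrogen would help to separate them.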